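Methyl in place of chloro on the phenoxy ring

The compounds below may be only part of what the source reports. "The series", "measured", "known", "first", "only" and "open" are said of these compounds alone.

In a functional assay on A549 cells (Homo sapiens) for cytotoxicity, read by trypan blue exclusion, with a stated time of 48 h (on this read-out higher numbers stand for weaker inhibition and lower numbers for stronger inhibition), compound 2 `O=C(COc1ccc(Cl)cc1)Nc1nc(-c2ccc(Cl)cc2)cs1` gives 49100 nM. Compound 1 `O=C(COc1ccc(Cl)cc1)Nc1nc(-c2ccc(Br)cc2)cs1` gives 46400 nM and compound 3 `Cc1ccc(-c2csc(NC(=O)COc3ccccc3C(C)C)n2)cc1` gives 44700 nM; all three numbers sit within the scatter of one another, so compound 2 cannot be set apart from the other two. Compound 4 `Cc1ccc(OCC(=O)Nc2nc(-c3ccc(Cl)cc3)cs2)cc1` differs from compound 2 by methyl in place of chloro on an aromatic carbon. Among the compounds with values here, no measured pair shows this exact change. Within the data shown here, the one single-change step available, a 1.1-fold higher number from compound 1 to compound 2 (0.02 log units; within the scatter), is a halogen swap and stays within the scatter, and compound 3, which also carries a methyl on an aromatic carbon, gives a number close to compound 2. The step of a 1.0-fold lower number from compound 2 to compound 4 (0.02 log units; within the scatter) is therefore expected to stay within the scatter. Compound 4 is estimated at 47000 nM, with a range from 24000 nM to 92000 nM.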

Compound 4, half-maximal inhibitory concentration: 44800 nM
For compound 4 the middle estimate is 1.0-fold (0.02 log units) above the measured one; the measured number falls inside the stated range.
By their numbers in this assay, from the lowest: compounds 3, 4, 1 and 2 (each within the scatter of the next).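

The 4-chlorophenoxy to 4-methylphenoxy change gives a 1.1-fold lower number from compound 2 to compound 4 (0.04 log units; within the scatter) in this assay. Within the data shown here, the only earlier single-change step was a halogen swap elsewhere in the molecule, so this is the first reading at this place, on the phenoxy ring, and here the read-out does not separate methyl from chloro. No measured evidence bears on this result.

Going by these compounds, whether an amine, a carboxylic acid or a longer chain at this place would move the number stays open. Also open, on these data alone, is whether methyl in place of chloro on the 4-chlorophenyl group would stay within the scatter.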